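A few compounds are considered here, and "the series" means these few. Any claim that something is new, unique, unknown or untested is made for them only; others in the source may bear on it.

Compound 1 `O=S(=O)(c1ccccc1)c1nc2ccccc2nc1N1CCCC1`: 3460 nM
Compound 2 `Cc1ccc(S(=O)(=O)c2nc3ccccc3nc2N2CCCC2)cc1`: 9720 nM
Compound 3 `O=S(=O)(c1ccccc1)c1nc2ccccc2nc1N1CCC(O)CC1`: 2900 nM

These three compounds were tested in a functional assay on HL-60 cells (Homo sapiens) for cytotoxicity, read by MTT assay, with a stated time of 72 h; on this read-out higher numbers stand for weaker inhibition and lower numbers for stronger inhibition. A fourth compound, compound 4 `Cc1ccc(S(=O)(=O)c2nc3ccccc3nc2N2CCC(O)CC2)cc1`, has not yet been measured in this assay. Compound 4 differs from compound 3 in one place: methyl in place of hydrogen on an aromatic carbon. The same change has already been made once, from compound 1 to compound 2, where it reads (methyl in place of hydrogen on an aromatic carbon). In this assay that step gave a 2.8-fold higher number from compound 1 to compound 2 (0.45 log units; beyond the scatter). The two starting points, compound 1 and compound 3, do not share the same core; they differ by 4-hydroxypiperidin-1-yl in place of pyrrolidin-1-yl on an aromatic carbon, a change that on its own gave a 1.2-fold lower number from compound 1 to compound 3 (0.08 log units; within the scatter). Both instances of the methyl change sit at the same place on the same kind of ring, so the change from compound 3 to compound 4 is the same change as that from compound 1 to compound 2. A step of similar size is expected, resting on a 2.8-fold higher number from compound 1 to compound 2 (0.45 log units; beyond the scatter) and on the starting value of compound 3, 2900 nM. The expected step is a 2.8-fold higher number from compound 3 to compound 4 (0.45 log units; beyond the scatter). Compound 4 is therefore estimated at 8100 nM, with a likely range from 4000 nM to 16000 nM.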

Compound 4, half-maximal inhibitory concentration: 4050 nM
For compound 4 the middle estimate is 2.0-fold (0.30 log units) above the measured one, and the stated range covers the measured number.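

Changing phenyl to 4-methylphenyl gives a 1.4-fold higher number from compound 3 to compound 4 (0.15 log units; within the scatter) in this assay, and this step stays close to the one seen on the other core: the same change on two cores in this assay, a 2.8-fold higher number (0.45 log units; beyond the scatter) from compound 1 to compound 2 and a 1.4-fold higher number (0.15 log units; within the scatter) from compound 3 to compound 4, 2.0-fold (0.30 log units) apart, within the scatter of two such steps. Changing pyrrolidin-1-yl to 4-hydroxypiperidin-1-yl gives a 2.4-fold lower number from compound 2 to compound 4 (0.38 log units; beyond the scatter), and this step also agrees with its earlier counterpart: the same change on two cores in this assay, a 1.2-fold lower number (0.08 log units; within the scatter) from compound 1 to compound 3 and a 2.4-fold lower number (0.38 log units; beyond the scatter) from compound 2 to compound 4, 2.0-fold (0.30 log units) apart, within the scatter of two such steps. Among the compounds shown here, each change therefore carries over between these two cores about as far as the scatter allows anyone to tell, but that rests on only two pairs per change, so it does not show that the steps are truly equal, that they would hold on a third core, or why they take the size they do.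

The compounds shown leave open whether a chlorine or a methoxy group in place of the methyl would follow the same course. They also leave open how a morpholine or a piperazine in place of the 4-hydroxypiperidin-1-yl would behave.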